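A few compounds are considered here, and "the series" means these few. Any claim that something is new, unique, unknown or untested is made for them only; others in the source may bear on it.

Series notes. Compound 1 `Nc1cc(N)c2nc(-c3ccccc3)c(Oc3ccc(Cl)c(Cl)c3)nc2c1` is the reference point. In a functional assay on OVCAR-4 cells (Homo sapiens) for inhibition, read by sulforhodamine B assay, with a stated time of 48 h (on this read-out lower numbers stand for higher toxicity in this test and higher numbers for lower toxicity in this test), compound 1 gives < 100000 nM, which is a limit of the test and not a number. Compound 2 `CCOC(=O)[C@H](CCC(=O)O)NC(=O)c1ccc(Sc2nc3cc(N)cc(N)c3nc2-c2ccccc2)cc1` in this assay gives < 100000 nM, again a limit and not a number. Within the data shown here, compound 3 `COc1ccc(CNc2nc3cc(N)cc(N)c3nc2-c2ccccc2)cc1` gives 47900 nM in this assay, the only actual number among the three. The other two sit at the limit of < 100000 nM in this assay, at which 2 of the 3 values shown sit, so compound 1 is placed only by that limit and cannot be ranked against compound 3. Among the measured compounds shown here, no step between two measured compounds that differ in a single place is available, so nothing in the set calibrates the change about to be considered. Compound 4 `Nc1cc(N)c2nc(-c3ccccc3)c(Oc3ccc(F)cc3)nc2c1` is the unmeasured member. The change from compound 1 to compound 4 is 4-fluorophenyl in place of 3,4-dichlorophenyl on an oxygen on an aromatic ring. With compound 1 known only as a limit, the expected step in this assay is none beyond the scatter, and the estimate for compound 4 is 60000 nM, with a range from 15000 nM to 100000 nM, the expected step from compound 1 to compound 4 being a step that the limit leaves unreadable from compound 1 to compound 4.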

Compound 4, concentration lethal to 50% of the cells: < 100000 nM
Compound 4: only a limit was reported; the forecaster's own chance of this, stated with the estimate: 50%; the middle value does not contradict the limit.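

Compound 1 and compound 4 are both held only by limits in this assay, so no step can be read between them: the limit of < 100000 nM in this assay, at which 3 of the 4 values shown sit. The compounds shown leave open how far 4-fluorophenyl in place of 3,4-dichlorophenyl moves this read-out, and where compound 1 and compound 4 stand against compound 3.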